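Methyl for methoxy on two different rings of an indole aldehyde series

The source may hold more compounds than are shown below. What is called first, only, known or untested is meant among the compounds shown, and "the series" means these compounds.

Measured so far:
compound 1, `COc1ccc(-c2[nH]c3ccc(OC)cc3c2C=O)cc1`: 260 nM
compound 2, `COc1ccc(-c2[nH]c3cc(Cl)ccc3c2C=O)cc1`: 27 nM
compound 3, `COc1ccc(-c2[nH]c3ccc(C)cc3c2C=O)cc1`: 86 nM

Of the compounds shown here, three have been tested in a functional assay on MDA-MB-231 cells (Homo sapiens) for antiproliferative activity, with a stated time of 4 days; a higher number here means a weaker inhibitor, a lower number a stronger inhibitor. Compound 1 `COc1ccc(-c2[nH]c3ccc(OC)cc3c2C=O)cc1` gives 260 nM in this assay, compound 3 `COc1ccc(-c2[nH]c3ccc(C)cc3c2C=O)cc1` gives 86 nM, and compound 2 `COc1ccc(-c2[nH]c3cc(Cl)ccc3c2C=O)cc1` gives 27 nM. Compound 2 has the lowest number of the three; its steps to compound 3 and to compound 1 are both beyond the scatter, so it stands as the strongest inhibitor measured here. The difference between the core of compound 1 and the core of compound 2 is not broken down here; their two values simply show compound 2 well ahead.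

One single change has been measured: methyl in place of methoxy on an aromatic carbon It made a 3.0-fold lower number from compound 1 to compound 3 (0.48 log units; beyond the scatter).

The untested compound 4 `Cc1ccc(-c2[nH]c3cc(Cl)ccc3c2C=O)cc1` carries the same kind of change relative to compound 2: methyl in place of methoxy on an aromatic carbon The surroundings differ, though. In going from compound 1 to compound 3 the place is part of a fused or bridged system of two rings, meta to a fused ring and para to a fused ring, whereas in compound 4 the place is on a ring of carbon only, para to a large group. So the earlier step is a guide only for the kind of change, not a warrant that its size will repeat.

Taking compound 2 at 27 nM as the start, a step of about a 1.5-fold lower number from compound 2 to compound 4 (0.18 log units; within the scatter) is expected, a little smaller than the earlier one because a 3.0-fold lower number from compound 1 to compound 3 (0.48 log units; beyond the scatter) was obtained at a different place. Compound 4 is therefore estimated at 18 nM, with a likely range from 6 nM to 60 nM.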

Compound 4, half-maximal inhibitory concentration: 7.8 nM
Compound 4: middle estimate off by 2.3-fold (0.36 log units), on the high side; measured number inside the range.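

In this assay, methyl in place of methoxy, this time on a six-membered aromatic ring of carbon only and para to a large group, gave a 3.5-fold lower number from compound 2 to compound 4 (0.54 log units; beyond the scatter). The change thus lowered the number at both places tested, and the two steps are close enough in size to be treated as the same within the scatter: the same change on two cores in this assay, a 3.0-fold lower number (0.48 log units; beyond the scatter) from compound 1 to compound 3 and a 3.5-fold lower number (0.54 log units; beyond the scatter) from compound 2 to compound 4, 1.1-fold (0.06 log units) apart, within the scatter of two such steps. Within the data shown here, this shows that in these two pairs the gain from the swap carried over from one core to the other, but two pairs make a small sample: the cores and the places of the change differ together, so the data cannot say how much either one matters, and they give no assurance that a step of this size would appear on a further core or in another assay.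

The compounds shown leave open whether the gain is particular to methyl or would also appear with an ethyl group, a longer chain, a chlorine atom or an amine at the same place. They also leave open what happens when the aldehyde gives way to a carboxylic acid or a nitrile, and whether methyl on both rings of one compound would add the two steps together.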